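This account rests on a few compounds, and the source may have more. Where it says the series, first, only, none or still open, it means among the compounds named here.

Of the compounds shown here, three have been measured in a functional assay on HEK293 cells for agonist activity at D(4) dopamine receptor (Homo sapiens), read by FLIPR; on this read-out lower numbers stand for smaller maximal responses and higher numbers for larger maximal responses. Compound 1, `Cc1cccc(C(=O)NCN2CCC(c3nccs3)CC2)c1`, gives 71% in this assay. Compound 2, `COc1ccccc1C1CCN(CC(=O)Nc2cccc(C)c2)CC1`, gives 43%. Compound 3, `Cc1cc(C)cc(NC(=O)CN2CCC(c3cccc[n+]3[O-])CC2)c1`, gives 76%, the highest of the three numbers; compound 1 lies within the scatter of compound 3, while compound 2 lies beyond the scatter, well under it.

Compound 4, `O=C(CN1CCC(c2cccc[n+]2[O-])CC1)Nc1ccc(F)cc1F`, has not yet been measured in this assay. It differs from compound 3 in one place, described as follows: 2,4-difluorophenyl in place of 3,5-dimethylphenyl on an amide-type nitrogen. Within the data shown here, no measured pair in this set shows the effect of such a change, and the three measured compounds differ from one another in more than one place, so no single step can be read off for guidance.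

For compound 4 the step from compound 3 is therefore expected to be small, and the estimate is that it will be a move of no more than a number 11 percentage points lower from compound 3 to compound 4 (beyond the scatter), not clearly beyond the scatter in either direction. Compound 4 is expected to give an efficacy of about 65% in this assay, with a range from 40% to 90%.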

Compound 4, largest response reached (reported as efficacy), in percent of the reference or control that the assay uses: 74%
The estimate for compound 4 lay 9 percentage points below the measured number; the measured number falls inside the stated range.
By their numbers in this assay, from the lowest: compound 2; then compounds 1, 4 and 3 (each within the scatter of the next).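

In this assay, among these compounds, placing 2,4-difluorophenyl instead of 3,5-dimethylphenyl on the amide-type nitrogen gives a number 2 percentage points lower from compound 3 to compound 4 (within the scatter), the first step in this set that isolates a change in one place. For this pair, the position accepts either of these two phenyl groups, which have the same heavy-atom count, without a difference that can be told from the scatter of the read-out. No independent measurement is available to explain why the two compounds read alike.

This single step replaces both the kind of group on the phenyl ring and the places those groups occupy, so the compounds shown cannot separate these two changes, and a 3,5-difluorophenyl group would be the direct comparison with 3,5-dimethylphenyl. As far as these compounds go, it also remains open whether the same position would accept something further from these two groups, such as a cyclohexyl ring or a phenyl ring carrying a carboxylic acid, and whether the step would read the same way on the core of another compound.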